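A Methoxy Added to Two Purine Cores

The source may hold more compounds than are shown below. What is called first, only, known or untested is meant among the compounds shown, and "the series" means these compounds.

Compound 1 `COc1ccc(N(C)c2ncnc3c2ncn3Cc2cc(OC)cc(OC)c2)cc1` and compound 2 `COc1ccc(N(C)c2ncnc3c2ncn3Cc2cc(OC)c(OC)c(OC)c2)cc1` share a core that differs from the core of compound 3 `COc1ccc(Cn2cnc3c(Cl)ncnc32)cc1` in a way that is not broken down here. In a functional assay on AGS cells (Homo sapiens) for antiproliferative activity, read by MTT assay, with a stated time of 48 h (on this read-out higher numbers stand for weaker inhibition of growth and lower numbers for stronger inhibition of growth), compound 1 gives only a limit of the assay, > 100000 nM. In this assay compound 2 likewise gives only a limit, > 100000 nM. The change between them, (methoxy in place of hydrogen on an aromatic carbon), therefore makes a step that the two limits leave unreadable from compound 1 to compound 2, which rests on (the limit of > 100000 nM in this assay, at which 2 of the 3 values shown sit). In this assay, for the measured compounds named here, compound 3 gives 29000 nM, the one number among the three. Compound 4 `COc1ccc(Cn2cnc3c(Cl)ncnc32)cc1OC` arises from compound 3 by the same kind of change, (methoxy in place of hydrogen on an aromatic carbon). The surroundings are not the same: in compound 2 the new group stands ortho to two methoxy groups and para to a large group, while in compound 4 it stands ortho to a methoxy group and meta to a large group. Going by the values given here, no measured step reads the size of this change. The expected step is a 1.0-fold higher number from compound 3 to compound 4 (0.01 log units; within the scatter), a size within the usual scatter, and this expectation rests only on compound 3 at 29000 nM. In this assay compound 4 is expected to give about 30000 nM, between 10000 nM and 90000 nM.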

Compound 4, concentration for 50% growth inhibition: > 100000 nM
Compound 4 was reported as a limit (the forecaster's own chance of this, stated with the estimate: 20%); middle value at least 3.3-fold (0.52 log units) away from the limit.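

In this assay compound 4 gives > 100000 nM, which is a limit of the assay and not a number. From the compounds shown here alone, on the core of compound 3, putting methoxy in place of hydrogen on an aromatic carbon therefore gives an at least 3.4-fold higher number from compound 3 to compound 4 (0.53 log units; beyond the scatter), so the added methoxy goes with weaker inhibition of growth on this core, although its full size stays unknown. This does not show that the change acts in the same way on both cores, since the matching step from compound 1 to compound 2 cannot be read and one core offers no size to set against the other, for the reason shown here: the limit of > 100000 nM in this assay, at which 3 of the 4 values shown sit.

For the compounds shown here, compound 3, at 29000 nM, is the only compound here with a number, so there is just one firm starting point in this assay. Open, going by these compounds, is whether a hydroxyl or an amine in place of that hydrogen, ortho to a methoxy group, would keep growth inhibition measurable on the core of compound 3.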